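Chloro to fluoro in a weakly active series

The source may report more compounds than this note shows. Statements on the series, on what has been measured and on what is new or still open speak of the compounds shown alone.

Measured in a functional assay on Bel-7402 cells (Homo sapiens) for inhibition, read by sulforhodamine B assay, with a stated time of 72 h; a higher number here means a weaker inhibitor, a lower number a stronger inhibitor:
- compound 1 `C[C@H](Nc1nc(N)nc(N)c1C#N)c1nn(-c2cccc(S(C)(=O)=O)c2)c2cc(F)ccc12`: 22100 nM
- compound 2 `Cc1ccc2c(c1)c([C@H](C)Nc1ncnc3[nH]cnc13)nn2-c1cccnc1`: > 40000 nM (a limit of the assay)
- compound 3 `C[C@H](Nc1ncnc2[nH]cnc12)c1nn(-c2cccnc2)c2cc(Cl)ccc12`: > 40000 nM (a limit of the assay)

Only compound 1 has a number. Compound 3 gives > 40000 nM, which is a limit and not a number, and its true position is therefore unknown. It shares the limit of > 40000 nM in this assay, at which 2 of the 3 values shown sit, with compound 2.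

Compound 4 `C[C@H](Nc1ncnc2[nH]cnc12)c1nn(-c2cccnc2)c2cc(F)ccc12` has fluoro in place of chloro on an aromatic carbon. The carbon belongs to a six-membered aromatic ring of carbon only, part of a fused or bridged system of two rings. Within the data shown here, no measured pair shows this change, so the expectation rests on compound 3 alone, with its limit of > 40000 nM. No step beyond the scatter is expected in this assay. The expected step is a number no higher from compound 3 to compound 4 (the limit leaves the size open), and a result reported only as a limit is the likeliest outcome. For compound 4 the estimated value is 40000 nM, within an expected range of 20000 nM to 80000 nM.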

Compound 4, half-maximal inhibitory concentration: > 40000 nM
Compound 4: only a limit was reported (the forecaster's own chance of this, stated with the estimate: 75%); the middle value lies on the limit itself.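

In this assay compound 3 and compound 4 are both reported only as limits, so no step can be read for fluoro in place of chloro: the limit of > 40000 nM in this assay, at which 3 of the 4 values shown sit. The compounds shown leave open where either compound truly lies and whether this change shifts inhibition at all.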